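The source may report more compounds than this note shows. Statements on the series, on what has been measured and on what is new or still open speak of the compounds shown alone.

Compound 1 `COc1cc(OC)c2sc(-c3ccc(N/C=C\C(=O)c4ccc(OC)c(O)c4)cc3)nc2c1`: 10600 nM
Compound 2 `COc1cc(OC)c2sc(-c3ccc(N/C=C\C(=O)c4ccc(OC)c([N+](=O)[O-])c4)cc3)nc2c1`: 5800 nM
Compound 3 `COc1cc(OC)c2sc(-c3ccc(N/C=C\C(=O)c4ccc(OC)c(F)c4)c(C)c3)nc2c1`: 15300 nM
Compound 4 `COc1cc(OC)c2sc(-c3ccc(N/C=C\C(=O)c4ccc(OC)c(F)c4)cc3)nc2c1`: not yet measured

In a functional assay on A549 cells (Homo sapiens) for antiproliferative activity, read by sulforhodamine B assay, with a stated time of 48 h (a lower number here means a stronger inhibitor, a higher number a weaker inhibitor), compound 3 gives 15300 nM. That is the highest number of the three, yet it lies within the scatter of compound 1 and beyond the scatter only from compound 2.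

Compound 4 hydrogen in place of methyl on an aromatic carbon has hydrogen in place of methyl on an aromatic carbon. For the measured compounds named here, no measured step makes this change. Going by the values given here, the one measured step, a 1.8-fold lower number from compound 1 to compound 2 (0.26 log units; within the scatter), swaps a different group and stays within the scatter, so it offers only weak guidance. No shift beyond the scatter is therefore expected in this assay.

The expected step is a 1.4-fold lower number from compound 3 to compound 4 (0.14 log units; within the scatter). For compound 4 the estimate is 11000 nM, with an expected range of 4500 nM to 25000 nM.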

Compound 4, half-maximal inhibitory concentration: 5300 nM
Beside the measured number, compound 4's estimate is 2.1-fold (0.32 log units) above it; the range from low to high includes it.
By their numbers in this assay, from the lowest: compounds 4, 2, 1 and 3 (each within the scatter of the next, the first and the last beyond it).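

In this assay, hydrogen in place of methyl on this aromatic carbon gives a 2.9-fold lower number from compound 3 to compound 4 (0.46 log units; beyond the scatter) and so shows that this single methyl matters, a step that lies beyond the scatter. With this carbon carrying hydrogen, fluoro can now be set against the other two groups on the far aromatic ring. Those swaps give a 1.1-fold lower number from compound 2 to compound 4 (0.04 log units; within the scatter) and a 2.0-fold lower number from compound 1 to compound 4 (0.30 log units; within the scatter) and both stay within the scatter, so fluoro, nitro and hydroxy cannot be told apart there.

As far as these compounds go, whether an ethyl or a methoxy on this carbon would act like methyl, or an amine in place of fluoro would stand apart, stays open. No measurement here accounts for the methyl step.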